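This account rests on a few compounds, and the source may have more. Where it says the series, first, only, none or still open, it means among the compounds named here.

Compound 2, `CSc1cnc(C(=O)CCCCCCc2ccccc2)o1`, stands only at a limit in an assay on HEK-293T cells for inhibition of diacylglycerol lipase-alpha (Homo sapiens), read by colorimetric assay; on this read-out lower numbers stand for stronger inhibition and higher numbers for weaker inhibition: its value of > 10000 nM is a limit of the assay, not a number. Compound 1, `CC(=O)c1cnc(C(=O)CCCCCCc2ccccc2)o1`, likewise gives > 10000 nM in this assay, again a limit. Among the measured compounds shown here, the only measured step is a step that the two limits leave unreadable from compound 1 to compound 2, which cannot be read because the limit of > 10000 nM in this assay, at which 2 of the 2 values shown sit, covers both of its ends. Compound 3, `COc1ccc(-c2cnc(C(=O)CCCCCCc3ccccc3)o2)cc1`, differs from compound 2 by 4-methoxyphenyl in place of methylsulfanyl on an aromatic carbon. For the measured compounds named here, no measured step bears on this change in this assay, so neither a direction nor a size beyond the scatter can be drawn from the data; what is known is that the shared core with a small group on that aromatic carbon has twice reached only the limit. Compound 3 is therefore expected to sit near the limit as well, with a step of an at least 1.2-fold lower number from compound 2 to compound 3 (0.09 log units; that floor lies within the scatter) that remains uncertain. The estimate for compound 3 in this assay is 8000 nM, with a range from 1500 nM to 30000 nM, and a real chance that only a limit is reported again.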

Compound 3, half-maximal inhibitory concentration: > 10000 nM
Compound 3: a limit, no number; the forecaster's own chance of this, stated with the estimate: 60%; middle value at least 1.2-fold (0.09 log units) from the limit.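

Among the compounds shown here, no step among compound 1, compound 2 and compound 3 can be read, because both ends of each step sit at a limit: the limit of > 10000 nM in this assay, at which 3 of the 3 values shown sit. The compounds shown leave open how any group on that aromatic carbon affects inhibition in this assay, since none yields a number.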